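Side-chain swap on the shared thiazole-free core, compound 4

This account rests on a few compounds, and the source may have more. Where it says the series, first, only, none or still open, it means among the compounds named here.

Measured so far in a functional assay (aorta) with Rattus norvegicus as the target; a higher number here means that more compound is needed for the effect, a lower number that less compound is needed:
compound 1 `COc1ccc(-c2nc(CNC(=O)CSc3ccccc3)sc2-c2ccc(OC)cc2)cc1` gives 4.2 uM
compound 2 `COc1ccc(-c2nc(CNC(=O)CSC)sc2-c2ccc(OC)cc2)cc1` gives 6 uM
compound 3 `COc1ccc(-c2nc(CNC(=O)C3=NNC(=O)CC3)sc2-c2ccc(OC)cc2)cc1` gives 7.3 uM

Compound 2 sits second highest of the three numbers. Its nearest neighbour is compound 3, with a 1.2-fold higher number from compound 2 to compound 3 (0.09 log units; within the scatter); its furthest is compound 1, with a 1.4-fold higher number from compound 1 to compound 2 (0.15 log units; within the scatter). The third step, a 1.7-fold higher number from compound 1 to compound 3 (0.24 log units; within the scatter), is likewise within the scatter, so the three carbonyl substituents tried so far give no separation in this assay.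

Compound 4 `CCOC(=O)/C=C/c1nc(-c2ccc(OC)cc2)c(-c2ccc(OC)cc2)s1` is the next candidate. Its change from compound 2: 2-(ethoxycarbonyl)ethenyl in place of ((((methylsulfanyl)methyl)carbonyl)amino)methyl on an aromatic carbon. Among the compounds with values here, this removes the amide chain altogether rather than varying the group on the carbonyl carbon, so no measured step covers it directly. Within the data shown here, the measured steps show only that changes at the carbonyl carbon stay within the scatter; they say nothing about the amide linker or the ring carbon it sits on. The expectation is therefore weak and the range is set wide, with a mild drift towards a higher number as a guess, a 1.3-fold higher number from compound 2 to compound 4 (0.12 log units; within the scatter). Compound 4 is estimated at 8 uM, between 2.5 uM and 25 uM.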

Compound 4, concentration for half-maximal effect: > 100 uM
Compound 4 was reported as a limit; the forecaster's own chance of this, stated with the estimate: 15%; middle value at least 12-fold (1.09 log units) away from the limit.
By their numbers in this assay, from the lowest: compounds 1, 2 and 3 (each within the scatter of the next). At a limit, above all of these: compound 4.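

In this assay compound 4 gives > 100 uM, which is a limit and not a number: the limit of > 100 uM in this assay, at which 1 of the 4 values shown sits. Putting 2-(ethoxycarbonyl)ethenyl in place of ((((methylsulfanyl)methyl)carbonyl)amino)methyl on the aromatic carbon gives an at least 16-fold higher number from compound 2 to compound 4 (1.22 log units; beyond the scatter), the first step shown that lies beyond the scatter. The earlier changes, all on the carbonyl carbon of the amide chain, stayed within the scatter, so this position responds to exchange of the whole chain, even though the group that leaves and the group that enters both have 7 heavy atoms and the hydrogen-bond donors go from 1 to 0.

The exchange removes the amide and the sulfur and brings in a double bond and an ethyl ester in one move, so the compounds shown do not tell which of these parts carries the step. A carboxylic acid or a primary amide in place of the ethyl ester, a saturated two-carbon chain in place of the ethenyl, and a plain aminomethyl group on the same aromatic carbon would each separate these parts.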